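Furan-to-Methoxyphenyl Exchange at a Saturated Ring Carbon

The compounds below may be only part of what the source reports. "The series", "measured", "known", "first", "only" and "open" are said of these compounds alone.

Compound 1 `CN1C[C@@H](c2cccs2)[C@@]2(Cc3ccccc3C2=O)[C@@]12C(=O)Nc1ccccc12`: 20%
Compound 2 `CN1C[C@@H](c2ccco2)[C@@]2(Cc3ccccc3C2=O)[C@@]12C(=O)Nc1ccccc12`: 33.5%

Of the compounds shown here, two have been measured in a functional assay on the whole organism (strain Wister albino) for inhibition, with Rattus norvegicus as the target, read by paw edema, with stated times of 1 h and 4 h, at a dose of 50 mg/kg by the intraperitoneal route; a higher number here means more inhibition at the dose given (going by the name of the read-out), a lower number less inhibition. Compound 1 gives 20%, and compound 2 gives 33.5%. For the measured compounds named here, the one step between them, a number 13.5 percentage points higher from compound 1 to compound 2 (beyond the scatter), sets compound 2 at the top of the two numbers available, with compound 1 as its only neighbour and lying beyond the scatter below it.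

Compound 3 `COc1ccc([C@@H]2CN(C)[C@]3(C(=O)Nc4ccccc43)[C@]23Cc2ccccc2C3=O)cc1` has not been measured in this assay. It differs from compound 2 by 4-methoxyphenyl in place of furan-2-yl on a saturated ring carbon. Going by the values given here, the only measured step, from compound 1 to compound 2, touched the same saturated ring carbon, but it exchanged one five-membered aromatic ring with one hetero atom for another of the same kind; the change now made brings in a six-membered aromatic ring of carbon only, so that step gives the direction only loosely. A modest movement in either direction, or none beyond the scatter, is therefore the expectation, and the estimated step is a number 1.5 percentage points higher from compound 2 to compound 3 (within the scatter). On that basis compound 3 is expected to give about 35%, with a likely range from 18% to 52%.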

Compound 3, a percentage reported as inhibition, in the whole organism at one dose (the size of the read-out at that dose, not a potency): 21.8%
Beside the measured number, compound 3's estimate is 13.2 percentage points above it; the measured number falls inside the stated range.
By their numbers in this assay, from the lowest: compounds 1 and 3 (each within the scatter of the next); then compound 2.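

In this assay, placing 4-methoxyphenyl in place of furan-2-yl on the saturated ring carbon gives a number 11.7 percentage points lower from compound 2 to compound 3 (beyond the scatter), so this position also responds when a six-membered aromatic ring of carbon only enters, and not just when one five-membered aromatic ring replaces another. For the compounds shown here, replacing thiophen-2-yl with the same 4-methoxyphenyl gives a number 1.8 percentage points higher from compound 1 to compound 3 (within the scatter), which leaves furan-2-yl as the only one of the three groups whose compound stands apart from the other two, while the thiophen-2-yl and 4-methoxyphenyl compounds cannot be separated despite their different rings. Nothing available here offers a reason for this pattern.

Going by these compounds, whether the lower number of compound 3 relative to compound 2 goes with the six-membered aromatic ring itself or with its methoxy group stays open, since the two enter together. A plain phenyl group would separate those two, and a cyclohexyl group or a chain ending in an amine at this carbon would show whether an aromatic ring is needed here at all.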